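Swapping 3,4-Diethoxyphenyl for Phenyl on a Shared Core

The source may hold more compounds than are shown below. What is called first, only, known or untested is meant among the compounds shown, and "the series" means these compounds.

Three compounds share one core and differ only in the group on a double-bonded chain carbon bound to a double-bonded chain carbon. In a functional assay, read by spectrophotometry, with a stated time of 5 min (a lower number here means a stronger inhibitor, a higher number a weaker inhibitor), compound 1 `CCOc1cc(/C=C/C(=O)C(=Cc2ccc(OC)c(OC)c2)C(=O)/C=C/c2ccc(O)c(OCC)c2)ccc1O` gives 53200000 nM, compound 2 `CCOc1cc(C=C(C(=O)/C=C/c2ccc(O)c(OCC)c2)C(=O)/C=C/c2ccc(O)c(OCC)c2)ccc1O` gives 96700000 nM, and compound 3 `CCOc1cc(/C=C/C(=O)C(=Cc2ccc(OCC)c(OCC)c2)C(=O)/C=C/c2ccc(O)c(OCC)c2)ccc1O` gives 61600000 nM. The numbers do not truly separate compound 3 from the other two, as the data show a 1.2-fold higher number from compound 1 to compound 3 (0.06 log units; within the scatter) and a 1.6-fold lower number from compound 2 to compound 3 (0.20 log units; within the scatter).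

The next structure is compound 4 `CCOc1cc(/C=C/C(=O)C(=Cc2ccccc2)C(=O)/C=C/c2ccc(O)c(OCC)c2)ccc1O`, which has phenyl in place of 3,4-diethoxyphenyl at that same place: phenyl in place of 3,4-diethoxyphenyl on a double-bonded chain carbon bound to a double-bonded chain carbon. All the measured changes at this place bear on the new one. Besides the two above, they include a 1.8-fold higher number from compound 1 to compound 2 (0.26 log units; within the scatter). Each stays within the scatter, so swapping one of these groups for another has not yet produced a clear change in this assay. However, no measured compound has plain phenyl here, so this is an extrapolation and the range should stay wide.

The expected result is a 1.0-fold lower number from compound 3 to compound 4 (0.01 log units; within the scatter), which means no real change in either direction. For compound 4, the estimated value is 60000000 nM, with an expected range from 30000000 nM to 120000000 nM.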

Compound 4, half-maximal inhibitory concentration: 91400000 nM
Beside the measured number, compound 4's estimate is 1.5-fold (0.18 log units) below it; low and high end bracket the measured number.
By their numbers in this assay, from the lowest: compounds 1, 3, 4 and 2 (each within the scatter of the next).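

In this assay phenyl in place of 3,4-diethoxyphenyl gives a 1.5-fold higher number from compound 3 to compound 4 (0.17 log units; within the scatter) and the same swap against the other two groups gives a 1.1-fold lower number from compound 2 to compound 4 (0.02 log units; within the scatter) and a 1.7-fold higher number from compound 1 to compound 4 (0.24 log units; within the scatter) within the same narrow band. The earlier compounds shown here all carried oxygen-linked groups on this ring, so they could only compare one such pattern with another, whereas compound 4 has a bare phenyl at this place, on a double-bonded chain carbon bound to a double-bonded chain carbon. Even with the ethoxy, methoxy and hydroxy groups all gone, no step at this position leaves the scatter, so these ring groups cannot be said to matter in this assay, and no other data are available to explain this flat result.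

As far as these compounds go, what remains open is whether a quite different group at this place, such as an amine or a carboxylic acid on the phenyl ring, or a longer chain in place of the ring, would move the number beyond the scatter. Whether changes elsewhere on the shared core would do so is also unanswered by these four compounds.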